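A few compounds are considered here, and "the series" means these few. Any claim that something is new, unique, unknown or untested is made for them only; others in the source may bear on it.

Compounds measured so far:
- compound 1, `COc1cc2ncnc(NCc3cccc(NC(=O)Nc4cccc(C)c4)c3)c2cc1OC`: 27100 nM
- compound 2, `COc1ccccc1NC(=O)Nc1cccc(CNc2ncnc3cc(OC)c(OC)cc23)c1`: 15200 nM

Both compounds were tested in a functional assay on A549 cells (Homo sapiens) for antiproliferative activity, read by MTT assay; on this read-out lower numbers stand for stronger inhibition and higher numbers for weaker inhibition. Compound 1 gives 27100 nM there, and compound 2 gives 15200 nM. The two lie within the scatter of each other, as a 1.8-fold lower number from compound 1 to compound 2 (0.25 log units; within the scatter) shows, so no order between them can be claimed. Compound 3, `COc1cc2ncnc(NCc3cccc(NC(=O)Nc4ccccc4F)c3)c2cc1OC`, has not yet been tested. Its difference from compound 2 is fluoro in place of methoxy on an aromatic carbon. Among the compounds with values here, the only measured step, from compound 1 to compound 2, exchanged a different group on the same amide-type nitrogen and stayed within the scatter, so it bears on this step only loosely. Within the data shown here, no measured pair exchanges methoxy for fluoro. The step of a 1.2-fold higher number from compound 2 to compound 3 (0.07 log units; within the scatter) is therefore expected to stay within the scatter. Compound 3 is estimated at 18000 nM, in the range 7000 nM to 45000 nM.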

Compound 3, half-maximal inhibitory concentration: 23800 nM
For compound 3 the middle estimate is 1.3-fold (0.12 log units) below the measured one; the range from low to high includes it.
By their numbers in this assay, from the lowest: compounds 2, 3 and 1 (each within the scatter of the next).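

In this assay, fluoro in place of methoxy on an aromatic carbon ortho to a large group gives a 1.6-fold higher number from compound 2 to compound 3 (0.19 log units; within the scatter), so at this position one heavy atom with no hydrogen-bond acceptor reads the same as two heavy atoms with one. With 2-fluorophenyl in place of 3-methylphenyl on the amide-type nitrogen, a 1.1-fold lower number from compound 1 to compound 3 (0.06 log units; within the scatter) is seen, which puts all three aryl groups shown on that nitrogen within the scatter of one another. No evidence is at hand that would explain these results.

On these data alone, whether an amine, a carboxylic acid or a longer alkoxy chain at this position would also stay within the scatter remains open. So does whether fluoro would read the same on the other carbons of this ring.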